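The source may hold more compounds than are shown below. What is called first, only, known or untested is meant among the compounds shown, and "the series" means these compounds.

Measured so far in a physicochemical assay for solubility, using the shake flask method, measured as kinetic solubility, with a stated time of 20 h, at pH 2; a higher number here means a more soluble compound, a lower number a less soluble compound:
Compound 1 `FC(F)(F)c1cccc(-c2nc3cnc(Nc4ccccn4)cc3[nH]2)c1` gives 21000 nM.
Compound 2 `FC(F)(F)c1ccc(Nc2cc3[nH]c(-c4cccc(C(F)(F)F)c4)nc3cn2)nc1` gives < 5000 nM, which is a limit of the assay rather than a number.

Compound 2 therefore stands only at a limit: its solubility is known to lie beyond the reach of this assay, and the exact figure is open. Within the pair, the step of an at least 4.2-fold lower number from compound 1 to compound 2 (0.62 log units; beyond the scatter) shows that the added trifluoromethyl went with a clearly lower reading, the size of which is itself bounded by the limit of < 5000 nM in this assay, at which 1 of the 2 values shown sits.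

Compound 3 `FC(F)(F)c1cccc(-c2nc3cnc(Nc4ccc(-c5nnn[nH]5)cn4)cc3[nH]2)c1` differs from compound 2 in one place: 1H-tetrazol-5-yl in place of trifluoromethyl on an aromatic carbon. Within the data shown here, this change removes the very group whose arrival marked the step of an at least 4.2-fold lower number from compound 1 to compound 2 (0.62 log units; beyond the scatter), so part of that drop is expected to reverse, while the entering 1H-tetrazol-5-yl has no measured counterpart here. For compound 3 the expected step is an at least 3.0-fold higher number from compound 2 to compound 3 (0.47 log units; beyond the scatter), upward in this assay. The estimate for compound 3 is 15000 nM, within 5000 nM to 50000 nM.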

Compound 3, solubility: < 5000 nM
Compound 3: no number, only a limit; the forecaster's own chance of this, stated with the estimate: 25%; at least 3.0-fold (0.47 log units) between middle value and limit.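

In this assay, the reading for compound 3 is again a limit of the assay and not a number, so a low reading at this place is no longer tied to trifluoromethyl alone. Against hydrogen on this aromatic carbon, two atoms from the ring nitrogen, 1H-tetrazol-5-yl gives an at least 4.2-fold lower number from compound 1 to compound 3 (0.62 log units; beyond the scatter), so in the two substituted compounds shown, each group goes with a lower reading than hydrogen. The step between the two substituted compounds cannot be read, because both readings are limits: the limit of < 5000 nM in this assay, at which 2 of the 3 values shown sit.

From the compounds shown here alone, how far compound 2 and compound 3 lie past that limit stays open, and with it whether the two groups differ at all. Also open, going by these compounds, is whether a carboxylic acid or an amine at this place would give a reading closer to that of compound 1.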